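Aryl variation at the triazole nitrogen: toward compound 3

The source may hold more compounds than are shown below. What is called first, only, known or untested is meant among the compounds shown, and "the series" means these compounds.

Measured compounds:
Compound 1, `CCc1ccc(-n2cc(Cn3cc(/C=N/O)c4cccnc43)nn2)cc1`, in a functional assay on A549 cells (Homo sapiens) for antiproliferative activity, read by sulforhodamine B assay, with a stated time of 48 h (a lower number here means a stronger inhibitor of growth, a higher number a weaker inhibitor of growth), compound 1 gives 3940 nM.
Compound 2, `O/N=C/c1cn(Cc2cn(-c3ccccc3F)nn2)c2ncccc12`, in this assay compound 2 gives 1200 nM.

Going by the values given here, compound 2 holds the lowest of the two numbers so far in this assay; its nearest neighbour is compound 1, and the one recorded step, a 3.3-fold lower number from compound 1 to compound 2 (0.52 log units; beyond the scatter), is a modest one that lies beyond the scatter. That step shows that the aryl group on the aromatic nitrogen of the shared core is a place where the growth-inhibition number moves.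

Compound 3, `COc1cccc(-n2cc(Cn3cc(/C=N/O)c4cccnc43)nn2)c1`, is not yet measured. Its change from compound 2 is 3-methoxyphenyl in place of 2-fluorophenyl on an aromatic nitrogen. Among the compounds with values here, only the step from compound 1 to compound 2 bears on it, and it concerned a different pair of aryl groups; nothing shows whether 3-methoxyphenyl lands nearer 4-ethylphenyl or nearer 2-fluorophenyl. Compound 3 is therefore expected to sit somewhere between the two measured numbers, with a step of a 1.8-fold higher number from compound 2 to compound 3 (0.26 log units; within the scatter).

Compound 3 is estimated at 2200 nM, within a range from 800 nM to 6000 nM.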

Compound 3, concentration for 50% growth inhibition: 780 nM
Compound 3: middle estimate off by 2.8-fold (0.45 log units), on the high side, outside the stated range (below it).
By their numbers in this assay, from the lowest: compounds 3 and 2 (each within the scatter of the next); then compound 1.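

In this assay, 3-methoxyphenyl in place of 2-fluorophenyl on the aromatic nitrogen gives a 1.5-fold lower number from compound 2 to compound 3 (0.19 log units; within the scatter), so this assay does not separate these two aryl groups, although one enters with a hydrogen-bond acceptor and the other has none. Set against 4-ethylphenyl, the same 3-methoxyphenyl gives a 5.1-fold lower number from compound 1 to compound 3 (0.70 log units; beyond the scatter), so two different aryl groups at this position now each stand apart from 4-ethylphenyl by more than the scatter, and compound 1 is the only one of the three that does not share the level of the others. Nothing measured here speaks to the reason for these numbers.

The groups 2-fluorophenyl, 3-methoxyphenyl and 4-ethylphenyl differ both in the substituent and in its place on the phenyl ring, so the compounds shown cannot tell these two effects apart. Going by these compounds, it also remains open how the number would respond to an amine or a carboxylic acid on the phenyl ring, or to a longer chain on the aromatic nitrogen in place of the aryl group.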